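The compounds below may be only part of what the source reports. "The series", "measured", "known", "first", "only" and "open" are said of these compounds alone.

Working notes on the series. In a functional assay on MGC-803 cells (Homo sapiens) for inhibition, read by CCK-8 assay, with a stated time of 48 h (a lower number here means a stronger inhibitor, a higher number a weaker inhibitor), compound 1 `COc1ccc(CN(C(=O)CSC(=S)N2CCN(C(=O)OC(C)(C)C)CC2)c2cc(OC)c(OC)c(OC)c2)cc1OC` reads > 20000 nM, which is a limit of the assay and not a number. Within the data shown here, compound 2 `COc1ccc(CN(C(=O)CSC(=S)N2CCN(C(=O)OC(C)(C)C)CC2)c2cc(OC)c(OC)c(OC)c2)cc1[N+](=O)[O-]` gives 880 nM, the only numerical value so far. Among the measured compounds shown here, the one measured step, with nitro in place of methoxy on an aromatic carbon, is an at least 22-fold lower number from compound 1 to compound 2 (1.35 log units; beyond the scatter), and it is large. Compound 3 `COc1ccc(CN(C(=O)CSC(=S)N2CCN(C(=O)OC(C)(C)C)CC2)c2cc(OC)c(OC)c(OC)c2)cc1O` carries hydroxy in place of nitro on the same aromatic carbon, ortho to a methoxy group: hydroxy in place of nitro on an aromatic carbon. For the measured compounds named here, that large step from compound 1 shows that this assay responds strongly to the group at this carbon, but no hydroxy compound has been measured, so it sets no firm direction. The expected change is small and uncertain, a 1.8-fold lower number from compound 2 to compound 3 (0.25 log units; within the scatter). The estimated value for compound 3 is 500 nM, with an expected range of 60 nM to 8000 nM.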

Compound 3, half-maximal inhibitory concentration: 82 nM
Compound 3: middle estimate off by 6.1-fold (0.79 log units), on the high side; the range from low to high includes it.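

In this assay, hydroxy in place of nitro at this carbon gives an 11-fold lower number from compound 2 to compound 3 (1.03 log units; beyond the scatter), so the nitro group seen earlier does not mark the best group of the three at this carbon. Removing only the methyl from the methoxy oxygen gives an at least 240-fold lower number from compound 1 to compound 3 (2.38 log units; beyond the scatter), which places hydroxy, nitro and methoxy in a clear order at this carbon, with the hydroxy compound giving the lowest number. The methoxy end of that order is a limit and not a number: the limit of > 20000 nM in this assay, at which 1 of the 3 values shown sits.

Going by these compounds, whether the low number depends on the hydroxy hydrogen remains open, as does how an amine or a carboxylic acid on the same carbon would read. Only this one carbon varies across the compounds shown, so whether the order holds with changes elsewhere on the shared core is also unsettled.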